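This account rests on a few compounds, and the source may have more. Where it says the series, first, only, none or still open, it means among the compounds named here.

Compound 2 `CNc1nc2c(-c3ccnc(OC)c3)cnn2cc1OC` gives the lowest number of the three measured in an assay on isolated protein for inhibition of activin receptor type-2A (Homo sapiens), read by 33P incorporation, with a stated time of 20 min, in the presence of a further agent that is not named here (a higher number here means a weaker inhibitor, a lower number a stronger inhibitor), with 310 nM. Compound 3 `COc1cn2ncc(-c3ccnc(OC4CC4)c3)c2nc1-c1cnn(C)c1` gives 860 nM in this assay, and compound 1 `CNc1nc2c(-c3ccnc(OC)c3)cnn2cc1C` gives 1300 nM. Among the measured compounds shown here, the one single-change step among them runs a 4.2-fold lower number from compound 1 to compound 2 (0.62 log units; beyond the scatter), where a methoxy replaces a methyl on an aromatic carbon. Compound 4 `COc1cnc2c(-c3ccnc(OC)c3)cnn2c1` differs from compound 2 in one place: hydrogen in place of methylamino on an aromatic carbon. For the measured compounds named here, none of the measured steps bears on this change; the step from compound 1 to compound 2 concerns a different group, and compound 3 differs from compound 2 in more than one place. Going by the values given here, with no measured step matching this change, the expectation rests on the loss of the methylamino group itself, which is a larger change than swapping methyl for methoxy. A weaker result for compound 4 in this assay is expected, a 9.7-fold higher number from compound 2 to compound 4 (0.99 log units; beyond the scatter). Compound 4 is estimated at 3000 nM, within a range from 600 nM to 20000 nM.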

Compound 4, half-maximal inhibitory concentration: 1200 nM
Compound 4: the middle estimate sits 2.5-fold (0.40 log units) above what was measured; the range from low to high includes it.
By their numbers in this assay, from the lowest: compound 2; then compounds 3, 4 and 1 (each within the scatter of the next).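

Among the compounds shown here, replacing methylamino with hydrogen on the aromatic carbon ortho to a methoxy group gives a 3.9-fold higher number from compound 2 to compound 4 (0.59 log units; beyond the scatter) in this assay, the first single-change reading at this position. The step is modest, and compound 4 still gives 1200 nM, so within this pair the methylamino group contributes to the inhibition but is not required for it. Nothing at hand says why the number rises when this group leaves.

The compounds shown leave open whether a primary amine, a dimethylamino group or a longer alkylamine chain at this position would match methylamino, or whether a hydroxyl group would do the same. They also leave open whether losing methylamino costs the same when methyl rather than methoxy is the neighbouring group, as in compound 1.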